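The source may hold more compounds than are shown below. What is called first, only, known or untested is meant among the compounds shown, and "the series" means these compounds.

Measured in an ADME assay on HCT-116 cells (Homo sapiens) for cytotoxicity, read by MTT assay; a lower number here means that less compound is tolerated, a higher number that more compound is tolerated:
Compound 1 `Cc1nc(-c2cccnc2)sc1-c1nnc(-c2ccc([N+](=O)[O-])cc2)o1`: > 100 ug/mL, a limit
Compound 2 `COc1ccccc1-c1nnc(-c2sc(-c3cccnc3)nc2C)o1`: > 100 ug/mL, a limit
Compound 3 `Cc1nc(-c2cccnc2)sc1-c1nnc(-c2cccc(Cl)c2Cl)o1`: > 100 ug/mL, a limit

Compound 3 has no number of its own, only the limit > 100 ug/mL. The two other measured compounds offer no number either, and the whole record is the limit of > 100 ug/mL in this assay, at which 3 of the 3 values shown sit. Compound 4 `Cc1ccc(-c2nnc(-c3sc(-c4cccnc4)nc3C)o2)cc1` has not been measured. It differs from compound 3 by 4-methylphenyl in place of 2,3-dichlorophenyl on an aromatic carbon, with 4-methylphenyl in place of 2,3-dichlorophenyl on an aromatic carbon. Within the data shown here, the one measured step at this place is a step that the two limits leave unreadable from compound 2 to compound 3, so it gives no size to carry over. No step beyond the scatter is expected in this assay, in either direction, because of the limit of > 100 ug/mL in this assay, at which 3 of the 3 values shown sit. The expected change is a step that the limit leaves unreadable from compound 3 to compound 4. For compound 4 the estimate is 120 ug/mL, with an expected range from 50 ug/mL to 250 ug/mL.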

Compound 4, half-maximal cytotoxic concentration: > 100 ug/mL
Compound 4 ended at the assay's limit (the forecaster's own chance of this, stated with the estimate: 75%); the middle value is on the limit's open side.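

In this assay no step can be read between compound 4 and compound 1, compound 2 or compound 3: the limit of > 100 ug/mL in this assay, at which 4 of the 4 values shown sit.

The compounds shown leave open whether any of the groups on the shared core changes the tolerated concentration at all.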